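The source may hold more compounds than are shown below. What is called first, only, known or untested is meant among the compounds shown, and "the series" means these compounds.

Of the compounds shown here, three have so far been measured in a functional assay on HL-60 cells (Homo sapiens) for cytotoxicity, read by MTT assay, with a stated time of 72 h; on this read-out lower numbers stand for stronger inhibition and higher numbers for weaker inhibition. Compound 2 `COc1cc(/C=C/C(=O)OCC(=O)Nc2ccc(Cl)cc2)cc(OC)c1OCc1ccc(Cl)c(Cl)c1` gives 73900 nM. Compound 1 `COc1ccc(NC(=O)COC(=O)/C=C/c2cc(OC)c(OCc3ccc(Cl)c(Cl)c3)c(OC)c2)cc1` gives only > 200000 nM, which is a limit of the assay and not a number. The two differ in one place, (methoxy in place of chloro on an aromatic carbon), and that change made an at least 2.7-fold higher number from compound 2 to compound 1 (0.43 log units; beyond the scatter). The size of that step is bounded only on one side, since it rests on (the limit of > 200000 nM in this assay, at which 1 of the 3 values shown sits). Compound 3 `O=C(COC(=O)/C=C/c1ccc(O)c(O)c1)Nc1ccc(Cl)cc1` gives 8100 nM, the lowest of the two numbers; how its core differs from that of compound 2 is not broken down here.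

Compound 4 `COc1ccc(NC(=O)COC(=O)/C=C/c2ccc(O)c(O)c2)cc1` has not yet been measured in this assay. It differs from compound 3 by methoxy in place of chloro on an aromatic carbon, the same change that separates compound 2 from compound 1. Because that change produced an at least 2.7-fold higher number from compound 2 to compound 1 (0.43 log units; beyond the scatter), a step of similar size is expected here, a 3.1-fold higher number from compound 3 to compound 4 (0.49 log units; beyond the scatter), although the earlier step is known only as a lower bound. Compound 4 is therefore estimated to give 25000 nM, expected to fall between 10000 nM and 80000 nM.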

Compound 4, half-maximal inhibitory concentration: 72100 nM
Estimate against measurement, compound 4: 2.9-fold (0.46 log units) below; the range from low to high includes it.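

In this assay, the change from 4-chlorophenyl to 4-methoxyphenyl on the second core gives an 8.9-fold higher number from compound 3 to compound 4 (0.95 log units; beyond the scatter). The number rises with this change on both cores, so the direction carries over in these two pairs and neither pair goes against it; set side by side, the two steps read: the same change on two cores in this assay, an at least 2.7-fold higher number (0.43 log units; beyond the scatter) from compound 2 to compound 1 and an 8.9-fold higher number (0.95 log units; beyond the scatter) from compound 3 to compound 4; the limit leaves it open whether they differ. This does not show that the size of the step carries over, nor that the direction would hold on a third core, because the earlier step rests on a value that is only a limit: the limit of > 200000 nM in this assay, at which 1 of the 4 values shown sits.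

The compounds shown leave open how other groups in the same place on the aromatic ring would read, such as a fluoro, an amine, a nitrile or a carboxylic acid. They also leave open how the two cores compare one change at a time, since the compounds on either core differ from those on the other in more than one place.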